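This account rests on a few compounds, and the source may have more. Where it says the series, first, only, none or still open, it means among the compounds named here.

Measured so far in a functional assay on DU-145 cells (Homo sapiens) for inhibition, read by trypan blue exclusion, with a stated time of 96 h; a higher number here means a weaker inhibitor of growth, a lower number a stronger inhibitor of growth:
- Compound 1 `Cc1ccc(CS/C(=C/c2ccc(F)c(C)c2)C(=O)c2ccc(Cl)cc2)cc1` gives 25000 nM
- Compound 2 `O=C(/C(=C\c1ccccc1OCc1ccccc1)S(=O)(=O)c1ccc(F)cc1)c1ccc(Cl)cc1` gives 1000 nM
- Compound 3 `COc1cc(C(=O)/C(=C\c2ccc(O)c([N+](=O)[O-])c2)SCc2ccc(Br)cc2)cc(OC)c1OC` gives 1000 nM

Compound 1 has the highest of these three numbers, which makes it the weakest inhibitor of growth among them. Compound 2 and compound 3 share one value, and each lies below compound 1 by a gap beyond the scatter.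

Compound 4 `Cc1ccc(CS/C(=C/c2c[nH]c3ccc(Br)cc23)C(=O)c2ccc(Cl)cc2)cc1` has not yet been measured. Compared with compound 1, it carries 5-bromo-1H-indol-3-yl in place of 4-fluoro-3-methylphenyl on a double-bonded chain carbon bound to a double-bonded chain carbon.

For the measured compounds named here, no two measured compounds differ in one place, so no measured step speaks to this change. Going by the values given here, a moderate move toward a lower number, beyond the scatter, is expected in this assay on thin support: compound 2 at 1000 nM and compound 3 at 1000 nM show only that relatives of compound 1 can read much lower. The expected change is a 5.0-fold lower number from compound 1 to compound 4 (0.70 log units; beyond the scatter) and remains an estimate. For compound 4 the expected value is 5000 nM within a range of 1000 nM to 25000 nM as estimated here.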

Compound 4, concentration for 50% growth inhibition: 1000 nM
The estimate for compound 4 lay 5.0-fold (0.70 log units) above the measured number; low and high end bracket the measured number.
By their numbers in this assay, from the lowest: compounds 2, 3 and 4 (each within the scatter of the next); then compound 1.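

In this assay, the place on a double-bonded chain carbon bound to a double-bonded chain carbon proves responsive: 5-bromo-1H-indol-3-yl in place of 4-fluoro-3-methylphenyl gives a 25-fold lower number from compound 1 to compound 4 (1.40 log units; beyond the scatter). For the compounds shown here, this is the first single change that can be read directly, and it shows that this place accepts a group with two aromatic rings and a hydrogen-bond donor while the number falls. Nothing measured here explains the step.

As far as these compounds go, it remains open which part of the entering group carries the step: the bromine, the ring nitrogen with its hydrogen, or the second ring. Whether an amine or a nitrile in place of the bromine would hold the number in this assay also remains unknown from the compounds shown.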